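A few compounds are considered here, and "the series" means these few. Any claim that something is new, unique, unknown or untested is made for them only; others in the source may bear on it.

Measured so far:
- compound 1, `CCCCCCCCC#C[C@@H](O)[C@@H](N)CO`: 13.7%
- compound 2, `CCCCC#CC(=O)[C@@H]1COC(C)(C)N1C(=O)OC(C)(C)C`: 9.08%
- compound 3, `CCCCCCCCC#CC(=O)[C@@H]1COC(C)(C)N1C(=O)OC(C)(C)C`: 15.2%

All three numbers come from an assay on CHO cells for inhibition of sphingosine kinase 1 (Homo sapiens), tested at 10 uM; on this read-out higher numbers stand for more inhibition at the one concentration tested (going by the name of the read-out) and lower numbers for less inhibition. In this assay compound 3 gives 15.2% and compound 2 gives 9.08%. These two share a core, and the change between them is hydrogen in place of butyl on a saturated chain carbon, four bonds along the chain from a triple-bonded carbon. The step it made is a number 6.1 percentage points lower from compound 3 to compound 2 (within the scatter), so the two values cannot be told apart with confidence.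

Compound 3 carries a protected core; a free amino alcohol stands in its place in compound 1. In this assay compound 1 gives 13.7%. How the two cores differ is not broken down here; the value of compound 1 and that of compound 3 lie within the usual scatter of each other, as does that of compound 2.

Compound 4, `CCCCC#C[C@@H](O)[C@@H](N)CO`, has not yet been measured. It is compound 1 with the same change that turns compound 3 into compound 2: hydrogen in place of butyl on a saturated chain carbon, four bonds along the chain from a triple-bonded carbon. Because the earlier step was a number 6.1 percentage points lower from compound 3 to compound 2 (within the scatter), a similarly small step is expected here, and since compound 1 already sits low on the read-out, the expected step from compound 1 to compound 4 is a number 4.2 percentage points lower from compound 1 to compound 4 (within the scatter). The estimate for compound 4 in this assay is 9.5%, expected to fall between 0% and 20%, a guess resting on a single earlier pair and therefore loose.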

Compound 4, a percentage reported as inhibition, at one concentration (the size of the read-out at that concentration, not a potency): "not active" (no number reported)
The entry for compound 4 holds no number; no gap can be computed for the estimate.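

In this assay, going by these compounds alone, compound 4 is reported only as "not active", without a number, so no step from compound 1 to compound 4 can be read. Nothing available here bears on this result. The compounds shown leave open how far compound 4 lies from compound 1, and whether hydrogen in place of butyl has the same size of effect on both cores.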